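The source may hold more compounds than are shown below. What is called first, only, known or untested is meant among the compounds shown, and "the series" means these compounds.

Compound 1 `O=C(CCCCCC(=O)Nc1ccc(NC(=O)Nc2ccc(Cl)c(C(F)(F)F)c2)cc1)NO`: > 10000 nM
Compound 2 `O=C(CCCC(=O)Nc1ccc(NC(=O)Nc2ccc(Cl)c(C(F)(F)F)c2)cc1)NO`: > 10000 nM
Compound 3 `O=C(Nc1ccc(Nc2ncc(C(=O)NO)cn2)cc1)Nc1ccc(Cl)c(C(F)(F)F)c1`: > 10000 nM

In a functional assay on SK-HEP1 cells (Homo sapiens) for inhibition, read by sulforhodamine B assay, with a stated time of 48 h (on this read-out higher numbers stand for weaker inhibition and lower numbers for stronger inhibition), compound 3 gives > 10000 nM, which is a limit of the assay and not a number. Compound 1 likewise gives only a limit, > 10000 nM. Compound 2 also gives only a limit, > 10000 nM. All three measured compounds share (the limit of > 10000 nM in this assay, at which 3 of the 3 values shown sit). Compound 4 `O=C(CCCCC(=O)Nc1ccc(NC(=O)Nc2ccc(Cl)c(C(F)(F)F)c2)cc1)NO` is still to be measured; it differs from compound 3 by (4-(hydroxycarbamoyl)butyl)carbonyl in place of 5-(hydroxycarbamoyl)pyrimidin-2-yl on a nitrogen on an aromatic ring. Within the data shown here, the steps that bear on this change, a step that the two limits leave unreadable from compound 1 to compound 3 and a step that the two limits leave unreadable from compound 2 to compound 3, cannot be read, so neither size nor direction can be drawn from them. Compound 4 is expected to stay near the limit as well, with an estimated step that the limit leaves unreadable from compound 3 to compound 4. For compound 4 the estimate is 15000 nM, between 5000 nM and 50000 nM.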

Compound 4, half-maximal inhibitory concentration: > 10000 nM
Compound 4: a limit, no number (the forecaster's own chance of this, stated with the estimate: 80%); the middle value is on the limit's open side.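

Among these compounds, compound 4 also gives only a limit, so no step between it and compound 1, compound 2 or compound 3 can be read: the limit of > 10000 nM in this assay, at which 4 of the 4 values shown sit. From the compounds shown here alone, how far these four compounds differ in this assay stays open.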